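The compounds below may be only part of what the source reports. "The series", "measured", "known", "first", "only" and "open" are said of these compounds alone.

Measured compounds:
- Compound 1 `Cc1cn(C2CC(N=[N+]=[N-])C(COC(=O)NCCCN)O2)c(=O)[nH]c1=O` gives in an ADME assay on the whole organism (serum) with Homo sapiens as the target (on this read-out higher numbers stand for a longer-lived compound and lower numbers for a shorter-lived compound), a reading of > 48 h, which is a limit of the assay rather than a number.
- Compound 2 `Cc1cn(C2CC(N=[N+]=[N-])C(COC(=O)OCCCN)O2)c(=O)[nH]c1=O` gives in this assay a reading of 0.133 h.

For the measured compounds named here, compound 2 therefore holds the only actual number in this assay; the other reading is the limit described as the limit of > 48 h in this assay, at which 1 of the 2 values shown sits. The two compounds share the same core and differ only at the carbonyl carbon, and that single difference gave an at least 360-fold lower number from compound 1 to compound 2 (2.55 log units; beyond the scatter).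

Compound 3 `Cc1cn(C2CC(N=[N+]=[N-])C(COC(=O)CCCN)O2)c(=O)[nH]c1=O` is not yet measured. It differs from compound 2 by 3-aminopropyl in place of 3-aminopropoxy on a carbonyl carbon. Going by the values given here, only one measured step bears on this position, the one from compound 1 to compound 2, and it was very large, showing that what sits on this carbonyl carbon can move the half-life by a great deal. The change to compound 3 again alters the group on that carbonyl carbon, this time removing the oxygen link of the 3-aminopropoxy group, so a step well beyond the scatter is expected, most likely towards a longer-lived compound: an 11-fold higher number from compound 2 to compound 3 (1.05 log units; beyond the scatter). For compound 3 the estimate in this assay is 1.5 h, with a range from 0.2 h to 10 h.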

Compound 3, half-life: 0.433 h
The estimate for compound 3 lay 3.5-fold (0.54 log units) above the measured number; the measured number falls inside the stated range.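

In this assay, replacing the 3-aminopropoxy group with 3-aminopropyl on the carbonyl carbon gives a 3.3-fold higher number from compound 2 to compound 3 (0.51 log units; beyond the scatter), so removing the oxygen link changes the half-life only modestly. Replacing (3-aminopropyl)amino with 3-aminopropyl at the same place gives an at least 110-fold lower number from compound 1 to compound 3 (2.04 log units; beyond the scatter), which shows that compound 3 does not close much of the gap left by the first step: among these three groups, (3-aminopropyl)amino alone stands far apart from the other two. The true size of that large step stays unknown because the reading for compound 1 is a limit and not a number: the limit of > 48 h in this assay, at which 1 of the 3 values shown sits.

The compounds shown leave open how long compound 1 actually lasts in serum, and they do not say which chemical change ends the life of compound 2 or compound 3. Going by these compounds, it also remains open whether the long half-life belongs to the nitrogen attached to the carbonyl carbon in general, which a longer chain on that nitrogen or a dimethylamine at the end of the chain could help to test.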